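Changing the Nitrogen-Bound Ring in a Weakly Active Series

The compounds below may be only part of what the source reports. "The series", "measured", "known", "first", "only" and "open" are said of these compounds alone.

Three related compounds have been tested in a functional assay on Hep 3B2 cells (Homo sapiens) for inhibition, read by sulforhodamine B assay, with a stated time of 72 h; on this read-out lower numbers stand for stronger inhibition and higher numbers for weaker inhibition. Compound 1 (`C[C@H](Nc1nc(N)nc2[nH]cnc12)c1nn(-c2cccnc2)c2cc(F)ccc12`) gives > 40000 nM, which is a limit of the assay and not a number. Compound 3 (`CC[C@H](Nc1ncnc2[nH]cnc12)c1nn(-c2cccnc2)c2cc(F)ccc12`) gives > 40000 nM, which is also a limit. Within the data shown here, compound 2 (`C[C@H](Nc1ncnc2[nH]cnc12)c1nn(-c2cccnc2)c2cc(F)ccc12`) gives 34500 nM, the only true number of the three, so it is the natural reference point.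

The next structure is compound 4 (`C[C@H](Nc1ncnc2[nH]cnc12)c1nn(-c2cc(F)cc(F)c2)c2cc(F)ccc12`), which has 3,5-difluorophenyl in place of pyridin-3-yl on an aromatic nitrogen.

Among the measured compounds shown here, only two measured steps are available, and neither involves this position. One exchanges amino for hydrogen on an aromatic carbon: an at least 1.1-fold lower number from compound 1 to compound 2 (0.06 log units; that floor lies within the scatter). The other adds a methyl to a saturated chain carbon: an at least 1.1-fold higher number from compound 2 to compound 3 (0.06 log units; that floor lies within the scatter). Both lie within the scatter, and they say little about size because the limit of > 40000 nM in this assay, at which 2 of the 3 values shown sit, leaves each known only from one side.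

For the measured compounds named here, with no measured precedent for this exchange, the starting point is compound 2 at 34500 nM, and no step beyond the scatter is expected. The estimated change is a 1.4-fold lower number from compound 2 to compound 4 (0.14 log units; within the scatter). Compound 4 is expected at about 25000 nM, with an estimated range from 9000 nM to 40000 nM.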

Compound 4, half-maximal inhibitory concentration: > 40000 nM
Compound 4: only a limit was reported; the forecaster's own chance of this, stated with the estimate: 35%; middle value at least 1.6-fold (0.20 log units) from the limit.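

Among the compounds shown, this is the only change at the aromatic nitrogen of the five-membered ring, and in this assay compound 4 gives > 40000 nM, which is a limit and not a number. Replacing pyridin-3-yl with 3,5-difluorophenyl at this position gives an at least 1.1-fold higher number from compound 2 to compound 4 (0.06 log units; that floor lies within the scatter). The exchange therefore shows no measurable gain in inhibition when a ring of carbon only, without a hydrogen-bond acceptor, takes the place of the pyridine ring, but the true size of the step cannot be read because the values gather at one ceiling: the limit of > 40000 nM in this assay, at which 3 of the 4 values shown sit.

The compounds shown leave open whether any group on this nitrogen can bring the number clearly below that limit, since only pyridin-3-yl and 3,5-difluorophenyl appear there. A plain phenyl ring would separate the loss of the ring nitrogen from the arrival of the two fluorines, and a phenyl ring carrying an amine or a carboxylic acid would show whether a quite different kind of group changes the picture in this series.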